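The source may hold more compounds than are shown below. What is called first, only, known or untested is meant among the compounds shown, and "the series" means these compounds.

Going by the values given here, in a functional assay on NZB5 cells (Homo sapiens) for inhibition, read by thymidine incorporation, with a stated time of 5 days (on this read-out higher numbers stand for weaker inhibition and lower numbers for stronger inhibition), compound 1 `CN(C)c1ccc([N+](=O)[O-])cc1S(=O)(=O)N(C)/N=C/c1cnn2ccc(C#N)cc12` gives 40 nM, the lowest number measured so far. Compound 3 `Cc1ccc(NC(=O)C(F)(F)F)cc1S(=O)(=O)N(C)/N=C/c1cnn2ccc(C#N)cc12` gives 2300 nM, a gap well beyond the scatter of repeated measurements. For compound 2 `Cc1ccc([N+](=O)[O-])cc1C(=O)N(C)/N=C/c1cnn2ccc(C#N)cc12` the assay reports only a limit, > 20000 nM. Compound 4 `CCc1ccc([N+](=O)[O-])cc1S(=O)(=O)N(C)/N=C/c1cnn2ccc(C#N)cc12` shares the core of compound 1 but carries ethyl in place of dimethylamino on an aromatic carbon, para to a nitro group (ethyl in place of dimethylamino on an aromatic carbon). Among the compounds with values here, no measured pair tests this swap directly, so any forecast is loose. Within the data shown here, a moderate loss in this assay is expected, meaning a higher number but a smaller gap than the one separating compound 3 from compound 1. The expected change is a 3.0-fold higher number from compound 1 to compound 4 (0.48 log units; beyond the scatter). For compound 4 the estimated value is 120 nM, with an expected range of 25 nM to 600 nM.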

Compound 4, half-maximal inhibitory concentration: 170 nM
The estimate for compound 4 lay 1.4-fold (0.15 log units) below the measured number; low and high end bracket the measured number.
By their numbers in this assay, from the lowest: compound 1; then compound 4; then compound 3. At a limit, above all of these: compound 2.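

Going by these compounds alone, this is the first step that changes a single place. In this assay, putting ethyl in place of dimethylamino on the aromatic carbon para to a nitro group gives a 4.3-fold higher number from compound 1 to compound 4 (0.63 log units; beyond the scatter). The loss is real but modest: the nitrogen of dimethylamino is not essential, since compound 4, with carbon only at this place, still gives 170 nM. Nothing measured here explains this step. Still open, going by these compounds, is how a methoxy group, a primary amine or a longer chain such as butyl would behave at this place.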